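The compounds below may be only part of what the source reports. "The series", "measured", "known", "first", "only" and "open" are said of these compounds alone.

Of the compounds shown here, three sharing a core have been tested in a functional assay on HCT-116 cells (Homo sapiens) for inhibition; on this read-out lower numbers stand for stronger inhibition and higher numbers for weaker inhibition. Compound 1 `COCCOc1cc(/C=C\c2ccc3ccccc3c2)ccc1OC` gives 2990 nM, the only one of the three with a true number. Compound 2 `FC(F)(F)c1ccc(/C=C\c2ccc3ccccc3c2)cc1` gives > 5000 nM, which is a limit of the assay and not a number. Compound 3 `C(=C\c1ccco1)\c1ccc2ccccc2c1` gives > 5000 nM, which is again a limit. Its place on the scale is therefore (the limit of > 5000 nM in this assay, at which 2 of the 3 values shown sit).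

Compound 4 `C(=C\c1ccc2ccccc2c1)\c1ccoc1` has not yet been measured. It has the same atoms as compound 3, joined differently, with furan-3-yl in place of furan-2-yl on a double-bonded chain carbon bound to a double-bonded chain carbon.

Going by the values given here, no measured pair shows what this swap does in this assay, so the expectation rests on the reading of compound 3, > 5000 nM. The expected change, a step that the limit leaves unreadable from compound 3 to compound 4, is none beyond the usual scatter, in either direction. For compound 4 the estimated value is 5500 nM, with an expected range of 2500 nM to 12000 nM.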

Compound 4, half-maximal inhibitory concentration: > 5000 nM
Compound 4 was reported as a limit; the forecaster's own chance of this, stated with the estimate: 70%; the middle value does not contradict the limit.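

Compound 3 and compound 4 are both reported only as limits, so no step between them can be read: the limit of > 5000 nM in this assay, at which 3 of the 4 values shown sit.

The compounds shown leave open whether furan-3-yl and furan-2-yl differ at all in strength of inhibition and, if they do, in which direction.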